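Swapping ethyl for phenyl on compound 3

The source may hold more compounds than are shown below. What is called first, only, known or untested is meant among the compounds shown, and "the series" means these compounds.

In an in vivo ADME assay on the whole organism (strain 129/SvEvBrd x C57BL/6) for pharmacokinetics, with Mus musculus as the target, at a dose of 1 mg/kg by the intravenous route (on this read-out lower numbers stand for slow clearance and higher numbers for fast clearance), compound 3 `CCc1[nH]c(C(C)=O)nc1[C@@H](O)[C@H](O)[C@H](O)CO` gives 17.3 mL/min/kg. Compound 1 `CC(=O)c1cccc([C@@H](O)[C@H](O)[C@H](O)CO)n1` gives 14 mL/min/kg, and compound 2 `CC(=O)c1nc([C@@H](O)[C@H](O)[C@H](O)CO)c(C)[nH]1` gives 7 mL/min/kg. Compound 3 and compound 1 lie within the scatter of each other, while the gap between compound 3 and compound 2 lies beyond the scatter, with compound 3 the higher of the two. Compound 4 `CC(=O)c1nc([C@@H](O)[C@H](O)[C@H](O)CO)c(-c2ccccc2)[nH]1` differs from compound 3 by phenyl in place of ethyl on an aromatic carbon. Among the measured compounds shown here, only one measured step bears on this spot: a 2.5-fold higher number from compound 2 to compound 3 (0.39 log units; beyond the scatter), a modest change made with methyl in place of hydrogen. For the measured compounds named here, no measured compound carries phenyl there, so that single step cannot set a direction. The expected change is a 1.2-fold lower number from compound 3 to compound 4 (0.06 log units; within the scatter), with no step beyond the scatter foreseen. For compound 4 the estimated clearance is 15 mL/min/kg, with an expected range from 6 mL/min/kg to 35 mL/min/kg.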

Compound 4, clearance: 23.9 mL/min/kg
Compound 4: the middle estimate sits 1.6-fold (0.20 log units) below what was measured, within the range that was stated.
By their numbers in this assay, from the lowest: compounds 2, 1, 3 and 4 (each within the scatter of the next, the first and the last beyond it).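

Phenyl at this position on the shared core stays within the scatter of ethyl (a 1.4-fold higher number from compound 3 to compound 4 (0.14 log units; within the scatter)), so clearance does not separate these two groups, even though phenyl brings a whole ring. Against methyl the change is larger (a 3.4-fold higher number from compound 2 to compound 4 (0.53 log units; beyond the scatter)) and lies beyond the scatter. Nothing available explains either step.

Still open, from the compounds shown here alone, is how clearance would respond to an amine or a carboxylic acid at this position. Also open, going by these compounds, is what a chlorine atom on the phenyl ring would do.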